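Cytotoxicity of three amines and a dimethylamino analogue

The compounds below may be only part of what the source reports. "The series", "measured", "known", "first", "only" and "open" are said of these compounds alone.

Compound 1 `CCNc1nc(C)c(-c2nc3ccccc3s2)c(N[C@@H]2C[C@H](CO)[C@@H](O)[C@H]2O)n1` gives 12000 nM in an ADME assay on cells (Homo sapiens) for cytotoxicity, read by polymerase chain reaction, with a stated time of 3 days; on this read-out higher numbers stand for lower toxicity in this test and lower numbers for higher toxicity in this test. Compound 2 `CCCNc1nc(C)c(-c2nc3ccccc3s2)c(N[C@@H]2C[C@H](CO)[C@@H](O)[C@H]2O)n1` gives > 25000 nM in this assay, which is a limit of the assay rather than a number. Compound 3 `Cc1nc(NCC2CC2)nc(N[C@@H]2C[C@H](CO)[C@@H](O)[C@H]2O)c1-c1nc2ccccc2s1` gives 8000 nM in this assay.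

Compound 3 stands at the lowest of the two numbers shown, with compound 1 nearest; the step of a 1.5-fold lower number from compound 1 to compound 3 (0.18 log units; within the scatter) stays within the scatter, so the two cannot be told apart. The step of an at least 3.1-fold lower number from compound 2 to compound 3 (0.49 log units; beyond the scatter) is beyond the scatter, and so is an at least 2.0-fold higher number from compound 1 to compound 2 (0.31 log units; beyond the scatter), though compound 2 sits at the limit of > 25000 nM in this assay, at which 1 of the 3 values shown sits.

Compound 4 `Cc1nc(N(C)C)nc(N[C@@H]2C[C@H](CO)[C@@H](O)[C@H]2O)c1-c1nc2ccccc2s1` differs from compound 3 in one place: dimethylamino in place of (cyclopropylmethyl)amino on an aromatic carbon. Going by the values given here, no measured step exchanges an amino group bearing one hydrogen for one bearing none, so the three steps above touch only the neighbouring region of the shared core and give no direct guide. With the numbers for compound 3 and compound 1 lying close together, the expected step of a 1.3-fold higher number from compound 3 to compound 4 (0.10 log units; within the scatter) for compound 4 is small. The estimate for compound 4 in this assay is 10000 nM, with a range from 4000 nM to 25000 nM.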

Compound 4, half-maximal cytotoxic concentration: 18000 nM
Estimate against measurement, compound 4: 1.8-fold (0.26 log units) below, and the stated range covers the measured number.
By their numbers in this assay, from the lowest: compounds 3, 1 and 4 (each within the scatter of the next, the first and the last beyond it). At a limit, above all of these: compound 2.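

In this assay, going by these compounds alone, the earlier steps only swapped one amino group bearing a hydrogen for another, whereas dimethylamino on this aromatic carbon between two ring nitrogen atoms has 0 hydrogen-bond donors, and the step of a 2.3-fold higher number from compound 3 to compound 4 (0.35 log units; beyond the scatter) shows that this exchange can separate two compounds. The step of a 1.5-fold higher number from compound 1 to compound 4 (0.18 log units; within the scatter), however, stays within the scatter, so losing the donor does not set compound 4 apart from the ethylamino compound, and the donor count alone does not sort these compounds. The step of an at least 1.3-fold lower number from compound 2 to compound 4 (0.14 log units; that floor lies within the scatter) has a floor that lies within the scatter, so it cannot be read as a real difference, and the value of compound 2 remains a limit of the assay: the limit of > 25000 nM in this assay, at which 1 of the 4 values shown sits.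

Compound 3 and compound 4 differ at once in the donor, the three-membered ring and the number of heavy atoms, so what lies behind their step remains open. A (cyclopropylmethyl)(methyl)amino group, which keeps the ring but carries no hydrogen on the nitrogen, would pull these apart, and a diethylamino group would show how a longer chain behaves without that hydrogen.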